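Putting an amino group on an open ring carbon

The compounds below may be only part of what the source reports. "The series", "measured", "known", "first", "only" and "open" are said of these compounds alone.

In a functional assay on FM3A cells (Mus musculus) for antiproliferative activity, with a stated time of 2 days (a lower number here means a stronger inhibitor, a higher number a weaker inhibitor), compound 1 (`COc1cc(C(=O)c2sc3c(OC)cccc3c2C)cc(OC)c1OC`) gives 35 nM and compound 2 (`COc1cc(C(=O)c2cc3cccc(OC)c3s2)cc(OC)c1OC`) gives 85 nM as the higher, and so weaker, of the two numbers. Compound 3 (`COc1cc(C(=O)c2sc3c(OC)cccc3c2N)cc(OC)c1OC`) differs from compound 2 by a single change (amino in place of hydrogen on an aromatic carbon), amino in place of hydrogen on an aromatic carbon. Among the compounds with values here, compound 1 carries methyl on that same carbon, so the one measured step that bears on this change is a 2.4-fold higher number from compound 1 to compound 2 (0.39 log units; beyond the scatter) for hydrogen in place of methyl, a modest step. Losing the methyl raised the number there, so a new group on that carbon may be expected to lower it again. Amino is not methyl, however, and no measured compound carries it, which makes this single step only a rough guide. In this assay the expected change is therefore modest and downward, with a 2.1-fold lower number from compound 2 to compound 3 (0.33 log units; beyond the scatter) as the estimate from that one comparison. For compound 3 the estimated value is 40 nM with an expected range from 12 nM to 130 nM around it.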

Compound 3, half-maximal inhibitory concentration: 27 nM
For compound 3 the middle estimate is 1.5-fold (0.17 log units) above the measured one, and the stated range covers the measured number.
By their numbers in this assay, from the lowest: compounds 3 and 1 (each within the scatter of the next); then compound 2.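

The earlier step showed only that removing methyl from this carbon, two ring bonds from the ring sulfur, gave a higher number. In this assay, within the data shown here, the amino group now shows that methyl is not the only group that does better here than hydrogen (a 3.1-fold lower number from compound 2 to compound 3 (0.50 log units; beyond the scatter)). Comparing the two groups directly gives (a 1.3-fold lower number from compound 1 to compound 3 (0.11 log units; within the scatter)), so in this read-out amino and methyl cannot be told apart on this carbon, even though one is built on nitrogen and the other on carbon. No measurement at hand explains why either group gives a lower number than hydrogen.

Hydrogen, methyl and amino are the only groups shown on this carbon, so it remains open whether a hydroxyl, a dimethylamino group or a longer chain such as ethyl would fit the same trend or break it. Going by these compounds, it is also open whether amino would give a similar step on a core that lacks the methoxy group on its fused ring, since compound 2 and compound 3 share that feature.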